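The source may hold more compounds than are shown below. What is called first, only, known or untested is meant among the compounds shown, and "the series" means these compounds.

Measured so far in an assay on nucleic acid for inhibition of Nucleic Acid, read by fluorescence, tested at 100 uM; a higher number here means more inhibition at the concentration tested (going by the name of the read-out), a lower number less inhibition:
compound 1 `CN(Cc1cn(CC(O)COC(=O)c2ccccc2)nn1)CC1CCCCC1`, 6%
compound 2 `CCCCN(CCCC)Cc1cn(CC(O)COCc2ccccc2)nn1`, 6%
compound 3 `CCCCCCCC(=O)OCC(O)Cn1cc(CN(CCCC)CCCC)nn1`, 71%

Compound 3 stands highest of the three; compound 1 and compound 2 each lie well below it, beyond the scatter. Among the measured compounds shown here, the only step between measured neighbours that differ in one place is a number 65 percentage points higher from compound 2 to compound 3 (beyond the scatter), heptylcarbonyl in place of benzyl on an oxygen on a saturated carbon. Compound 4 `CCCCN(CCCC)Cc1cn(CC(O)COC(=O)c2ccccc2)nn1` is not yet measured and differs from compound 3 by phenyl in place of heptyl on a carbonyl carbon. For the measured compounds named here, no measured step covers this exchange directly. Compound 1, which also carries benzoyl, gives 6% in this assay. A fall is therefore expected for compound 4, a number 56 percentage points lower from compound 3 to compound 4 (beyond the scatter). The estimate for compound 4 is 15%, with a range of 3% to 45%.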

Compound 4, a percentage reported as inhibition, at one concentration (the size of the read-out at that concentration, not a potency): 12%
Compound 4: the middle estimate sits 3 percentage points above what was measured; measured number inside the range.
By their numbers in this assay, from the lowest: compounds 1, 2 and 4 (each within the scatter of the next); then compound 3.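

In this assay the heptyl on this carbonyl carbon cannot be exchanged for phenyl without a large loss (a number 59 percentage points lower from compound 3 to compound 4 (beyond the scatter)), so an ester alone does not keep the number high. With benzoyl in place, the ester and the benzyl ether are not told apart (a number 6 percentage points higher from compound 2 to compound 4 (within the scatter)), nor are the two amines (a number 6 percentage points higher from compound 1 to compound 4 (within the scatter)). No measurement on hand explains the loss.

Open, from the compounds shown here alone, is how the number responds to a shorter or longer chain on the carbonyl carbon, or to cyclohexyl there. Also open, going by these compounds, is whether heptylcarbonyl keeps its number with (cyclohexylmethyl)(methyl)amino in place of dibutylamino.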